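The source may report more compounds than this note shows. Statements on the series, on what has been measured and on what is new or still open speak of the compounds shown alone.

Measured so far in a functional assay on A549 cells (Homo sapiens) for antiproliferative activity, read by MTT assay, with a stated time of 48 h; a higher number here means a weaker inhibitor, a lower number a stronger inhibitor:
compound 1, `Cc1ccc2nc(NC(c3cn(-c4ccccc4)nc3-c3cccc(Cl)c3)c3c(O)ccc4ccccc34)sc2c1`, 45400 nM
compound 2, `Oc1ccc2ccccc2c1C(Nc1nc2ccc(Cl)cc2s1)c1cn(-c2ccccc2)nc1-c1cccc(Cl)c1`, 33300 nM
compound 3, `O=[N+]([O-])c1ccc(-c2nn(-c3ccccc3)cc2C(Nc2nc3ccc(Cl)cc3s2)c2c(O)ccc3ccccc23)cc1`, 57200 nM

Compound 4, `Cc1ccc2nc(NC(c3cn(-c4ccccc4)nc3-c3ccc([N+](=O)[O-])cc3)c3c(O)ccc4ccccc34)sc2c1`, is not yet measured. It differs from compound 3 by methyl in place of chloro on an aromatic carbon. The same change, at the same place, links compound 2 to compound 1: methyl in place of chloro on an aromatic carbon, where it gave a 1.4-fold higher number from compound 2 to compound 1 (0.13 log units; within the scatter). The cores of compound 2 and compound 3 differ in turn by 4-nitrophenyl in place of 3-chlorophenyl on an aromatic carbon, which gave a 1.7-fold higher number from compound 2 to compound 3 (0.23 log units; within the scatter). All three measured numbers sit within the scatter of one another, so no order among them is claimed. Because the earlier step was a 1.4-fold higher number from compound 2 to compound 1 (0.13 log units; within the scatter), the step from compound 3 to compound 4 is expected to be about a 1.2-fold higher number from compound 3 to compound 4 (0.09 log units; within the scatter), a move that stays within the scatter. Compound 4 is therefore estimated at 70000 nM, between 35000 nM and 140000 nM.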

Compound 4, half-maximal inhibitory concentration: 29000 nM
Compound 4: middle estimate off by 2.4-fold (0.38 log units), on the high side, outside the stated range (below it).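

In this assay, going from 6-chloro-1,3-benzothiazol-2-yl to 6-methyl-1,3-benzothiazol-2-yl gives a 2.0-fold lower number from compound 3 to compound 4 (0.29 log units; within the scatter), and this change does not carry over unaltered from the other core: the same change on two cores in this assay, a 1.4-fold higher number (0.13 log units; within the scatter) from compound 2 to compound 1 and a 2.0-fold lower number (0.29 log units; within the scatter) from compound 3 to compound 4, 2.7-fold (0.43 log units) apart, beyond the scatter of two such steps. Likewise, 4-nitrophenyl in place of 3-chlorophenyl gives a 1.6-fold lower number from compound 1 to compound 4 (0.19 log units; within the scatter), which also depends on the core: the same change on two cores in this assay, a 1.7-fold higher number (0.23 log units; within the scatter) from compound 2 to compound 3 and a 1.6-fold lower number (0.19 log units; within the scatter) from compound 1 to compound 4, 2.7-fold (0.43 log units) apart, beyond the scatter of two such steps. The two changes are therefore not independent across these four compounds, yet each single step lies within the scatter, and the set gives neither a rule for the wider series nor a cause for the gap.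

Still open, as far as these compounds go, is how fluoro, methoxy or an amine would behave in the place held by chloro and methyl. From the compounds shown here alone, a carboxylic acid in place of the nitro group on the phenyl ring is equally open.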